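A 4-fluorophenyl group replaces cyclopropyl in compound 1

A few compounds are considered here, and "the series" means these few. Any claim that something is new, unique, unknown or untested is made for them only; others in the source may bear on it.

In an in vitro ADME assay on microsomes from liver (Homo sapiens) for metabolic stability (on this read-out higher numbers stand for a longer-lived compound and lower numbers for a shorter-lived compound), compound 1 `CC(C)CC1n2cncc2CN(CC2CC2)S1(=O)=O` gives 0.917 h as the higher of two exact numbers, and compound 3 `COC(C)(C)CC1n2cncc2CN([C@@H](C)c2ccc(Cl)cc2)S1(=O)=O` gives the lower 0.2 h in a gap beyond the scatter. Compound 2 `CC(C)CC1n2cncc2CN(C2CC2)S1(=O)=O` shows > 6.75 h as a limit of the assay, not a number. Compound 4 `CC(C)CC1n2cncc2CN(Cc2ccc(F)cc2)S1(=O)=O` has 4-fluorophenyl in place of cyclopropyl on a saturated chain carbon bound to a sulfonamide nitrogen in a ring. Within the data shown here, the only measured single change (an at least 7.3-fold higher number from compound 1 to compound 2 (0.86 log units; beyond the scatter)) lies beyond the scatter but is a different swap, so it bears only loosely. Compound 3 also carries an aromatic ring on that chain and gives 0.2 h despite other differences, so a modest drop in this assay is expected. The expected step (a 2.3-fold lower number from compound 1 to compound 4 (0.36 log units; beyond the scatter)) is downward. Compound 4 is estimated at 0.4 h (range 0.12 h to 1.2 h).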

Compound 4, half-life: 0.0833 h
For compound 4 the middle estimate is 4.8-fold (0.68 log units) above the measured one; measured number outside the range, below it.
By their numbers in this assay, from the lowest: compound 4; then compound 3; then compound 1. At a limit, above all of these: compound 2.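

Swapping cyclopropyl for 4-fluorophenyl on the saturated chain carbon bound to the sulfonamide nitrogen shortens the compound's life in this assay by a large step (an 11-fold lower number from compound 1 to compound 4 (1.04 log units; beyond the scatter)). The earlier single change at this nitrogen went upward, so with the shared core held constant, the group carried here can move the half-life strongly in either direction. No measurement shown accounts for this drop.

On these data alone, it remains open whether the fluorine or the aromatic ring itself goes with the loss. A plain phenyl in the same place would separate the two, and an amine or a carboxylic acid there would test quite different groups.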